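Aryl variation on the shared core: notes toward compound 4

The source may hold more compounds than are shown below. What is called first, only, known or untested is meant among the compounds shown, and "the series" means these compounds.

Measured so far:
compound 1 `CC(=O)Nc1cccc(C2CCN(CCCn3c(-c4ccccc4C(F)(F)F)nc4ccccc43)CC2)c1`, 50 nM
compound 2 `CC(=O)Nc1cccc(C2CCN(CCCn3c(-c4cccc(C(F)(F)F)c4)nc4ccccc43)CC2)c1`, 30 nM
compound 3 `CC(=O)Nc1cccc(C2CCN(CCCn3c(-c4ccc(C#N)cc4)nc4ccccc43)CC2)c1`, 16 nM

In an assay for displacement of a labelled ligand from melanin-concentrating hormone receptor 1 (Homo sapiens), read by fluorescence (a higher number here means a weaker inhibitor, a lower number a stronger inhibitor), compound 1 gives 50 nM, the highest of the three numbers. Compound 2 stands nearest, with a 1.7-fold lower number from compound 1 to compound 2 (0.22 log units; within the scatter). Compound 3 stands furthest, with a 3.1-fold lower number from compound 1 to compound 3 (0.49 log units; beyond the scatter). Compound 2 and compound 3 are separated by a 1.9-fold lower number from compound 2 to compound 3 (0.27 log units; within the scatter).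

Compound 4 `CC(=O)Nc1cccc(C2CCN(CCCn3c(-c4ccc(F)c(F)c4)nc4ccccc43)CC2)c1` has not yet been measured. It differs from compound 1 as follows: 3,4-difluorophenyl in place of 2-(trifluoromethyl)phenyl on an aromatic carbon.

Both measured steps from compound 1 replace the 2-(trifluoromethyl)phenyl with a differently substituted phenyl and lead to a lower number, one within the scatter and one modestly beyond it. Compound 4 again carries a differently substituted phenyl, the 3,4-difluorophenyl, at the same aromatic carbon of the shared core. A lower number than compound 1 is therefore expected, of a size between those two steps, as a 2.0-fold lower number from compound 1 to compound 4 (0.30 log units; within the scatter). For compound 4 the expected value in this assay is 25 nM, with a range from 10 nM to 60 nM.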

Compound 4, half-maximal inhibitory concentration: 4 nM
Compound 4: middle estimate off by 6.3-fold (0.80 log units), on the high side; the whole stated range lies above it.
By their numbers in this assay, from the lowest: compound 4; then compounds 3, 2 and 1 (each within the scatter of the next, the first and the last beyond it).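

In this assay, within the data shown here, the 3,4-difluorophenyl gives the only step at this aromatic carbon printed as large, a 13-fold lower number from compound 1 to compound 4 (1.10 log units; beyond the scatter), so an aryl change here can move the number much further than the earlier compounds showed. The new group also separates compound 4 beyond the scatter from both other aryl variants, with a 4.0-fold lower number from compound 3 to compound 4 (0.60 log units; beyond the scatter) and a 7.5-fold lower number from compound 2 to compound 4 (0.88 log units; beyond the scatter), making compound 4 the strongest inhibitor of the four, whereas the 4-cyanophenyl and 3-(trifluoromethyl)phenyl compounds remain within the scatter of each other. No measurement at hand explains this difference.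

Whether both fluorine atoms are needed remains open, since no phenyl with a single fluorine is among the compounds shown. Also open, going by these compounds, is how this aromatic carbon tolerates a phenyl bearing two chlorine atoms, a methoxy group or an amine.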